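Tolerated concentrations in the series: compound 2 to compound 3

The compounds below may be only part of what the source reports. "The series", "measured", "known", "first", "only" and "open" are said of these compounds alone.

Compound 1, `CC(C)(C)OC(=O)Nc1ncc(C(Oc2ccc(Cc3ccccc3)cc2)c2ccc(Cl)cc2)s1`: > 50000 nM
Compound 2, `COC(=O)CCCCNc1ncc(C(Oc2ccc3cc(Br)ccc3c2)c2ccc(Cl)cc2)s1`: "not toxic" (no number reported)

Both entries come from an ADME assay on HepG2 2.2.15 cells (Homo sapiens) for cytotoxicity; a higher number here means that more compound is tolerated, a lower number that less compound is tolerated. For compound 1 the entry > 50000 nM is a limit of the assay and not a number. For compound 2 only the description "not toxic" (no number reported) is reported, without a number, so compound 2 cannot be placed on a scale; the only anchor in this set is the limit of > 50000 nM in this assay, at which 1 of the 2 values shown sits. For the measured compounds named here, no step between measured compounds can be computed.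

Compound 3, `O=S(=O)(Nc1ncc(C(Oc2ccc3cc(Br)ccc3c2)c2ccc(Cl)cc2)s1)c1cccs1`, differs from compound 2 by (thiophen-2-yl)sulfonyl in place of 4-(methoxycarbonyl)butyl on a nitrogen on an aromatic ring. For the change from compound 2 to compound 3 in this assay no shift beyond the scatter is expected, because compound 2 is recorded as "not toxic" (no number reported) and nothing shown points the other way. Compound 3 is therefore estimated at 60000 nM, expected between 20000 nM and 200000 nM, and most likely reported only as a limit.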

Compound 3, half-maximal cytotoxic concentration: "not toxic" (no number reported)
No number was reported for compound 3; the estimate stays without a comparison.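

For the compounds shown here, compound 2 and compound 3 are both recorded only as a description without a number, so no step between them can be read. The compounds shown leave open at what concentration, if any, either becomes toxic, and whether exchanging 4-(methoxycarbonyl)butyl for (thiophen-2-yl)sulfonyl changes that concentration.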